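This account rests on a few compounds, and the source may have more. Where it says the series, first, only, none or still open, it means among the compounds named here.

Working notes on the series. Compound 1 `CCCn1c(=O)[nH]c2nc(-c3ccc(S(=O)(=O)N4CCN(c5cccc(Cl)c5)CC4)cc3)[nH]c2c1=O`, compound 2 `CCCn1c(=O)[nH]c2nc(-c3ccc(S(=O)(=O)N4CCN(c5ccccc5Br)CC4)cc3)[nH]c2c1=O` and compound 3 `CCCn1c(=O)[nH]c2nc(-c3ccc(S(=O)(=O)N4CCN(c5cccc(Br)c5)CC4)cc3)[nH]c2c1=O` share one core and differ only in the aryl group carried on the amine nitrogen of the six-membered non-aromatic ring with two nitrogens. In an assay on CHO cells for displacement of a labelled ligand from adenosine receptor A1 (Homo sapiens), read by scintillation counting, with a stated time of 90 min, in the presence of a further agent that is not named here (on this read-out lower numbers stand for stronger inhibition and higher numbers for weaker inhibition), compound 1 gives > 1000 nM, which is a limit of the assay and not a number. Compound 2 is likewise reported only as a limit, > 1000 nM. Compound 3 too is reported only as a limit, > 1000 nM. The steps a step that the two limits leave unreadable from compound 1 to compound 2, a step that the two limits leave unreadable from compound 1 to compound 3 and a step that the two limits leave unreadable from compound 2 to compound 3 therefore cannot be read. Compound 3 stands where the whole set stands, because of the limit of > 1000 nM in this assay, at which 3 of the 3 values shown sit.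

Compound 4 `CCCn1c(=O)[nH]c2nc(-c3ccc(S(=O)(=O)N4CCN(c5ccc(C)cc5)CC4)cc3)[nH]c2c1=O` differs from compound 3 in one place: 4-methylphenyl in place of 3-bromophenyl on an amine nitrogen in a ring. Within the data shown here, none of the measured steps carries a readable size, so nothing in the set fixes a direction or a size for this change in this assay; the three limits are the only bearing on it. Compound 4 is therefore expected to remain at the limit as well, with the expected step that the limit leaves unreadable from compound 3 to compound 4 not resolvable against the scatter. Compound 4 is estimated to give 2500 nM, within the range 700 nM to 10000 nM.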

Compound 4, inhibition constant: > 1000 nM
Compound 4 gave a limit, no number; the forecaster's own chance of this, stated with the estimate: 80%; the middle value does not contradict the limit.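

In this assay compound 4 gives > 1000 nM, a limit and not a number. Among these compounds, no step between compound 4 and compound 1, compound 2 or compound 3 can be read, because all four compounds sit at one value: the limit of > 1000 nM in this assay, at which 4 of the 4 values shown sit. The compounds shown leave open how strongly any of the four inhibits, and whether any aryl group on the amine nitrogen gives a readable value.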